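Swapping a methyl for a catechol on the benzylamine

The compounds below may be only part of what the source reports. "The series", "measured", "known", "first", "only" and "open" are said of these compounds alone.

Compound 1 `C=C1CC[C@@H]2[C@](C)(CO)[C@H](O)CC[C@@]2(C)[C@@H]1CC=O`: > 30000 nM
Compound 2 `C=C1CC[C@@H]2[C@](C)(CO)[C@H](O)CC[C@@]2(C)[C@@H]1C/C=C(/C(=O)O)[C@H](O)CO`: > 30000 nM
Compound 3 `C=C1CC[C@@H]2[C@](C)(CNCc3ccc(C)cc3)[C@H](O)CC[C@@]2(C)[C@@H]1/C=C/C1=CCOC1=O`: 740 nM

Compound 1 reaches only a limit in a functional assay on BMMC cells (Mus musculus, strain C57BL/6) for inhibition, with stated times of 5 days and 48 h (a lower number here means a stronger inhibitor, a higher number a weaker inhibitor), > 30000 nM. Compound 2 likewise stops at a limit, > 30000 nM. Within the data shown here, compound 3 is the single compound with a measured number, 740 nM, while the other two sit at the limit of > 30000 nM in this assay, at which 2 of the 3 values shown sit. Compound 4 `C=C1CC[C@@H]2[C@](C)(CNCc3ccc(O)c(O)c3)[C@H](O)CC[C@@]2(C)[C@@H]1/C=C/C1=CCOC1=O` differs from compound 3 in one place: 3,4-dihydroxyphenyl in place of 4-methylphenyl on a saturated chain carbon bound to an amine nitrogen. Among the measured compounds shown here, no measured pair shows this kind of change, so there is no earlier step to lean on. The expectation for compound 4 in this assay is a step of a 1.1-fold higher number from compound 3 to compound 4 (0.03 log units; within the scatter) that stays within the usual scatter, in no clear direction. Compound 4 is therefore estimated at 800 nM, between 200 nM and 3500 nM.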

Compound 4, half-maximal inhibitory concentration: 9440 nM
For compound 4 the middle estimate is 12-fold (1.07 log units) below the measured one; measured number above the stated range.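

In this assay the group on the saturated chain carbon bound to an amine nitrogen clearly matters: 3,4-dihydroxyphenyl in place of 4-methylphenyl brings a 13-fold higher number from compound 3 to compound 4 (1.11 log units; beyond the scatter) and so a weaker inhibitor. Among these compounds, this is the first change at this position that can be read, and it shows that inhibition responds to what the ring carries. Compound 4 still gives a measured number and does not sit at the assay's limit: the limit of > 30000 nM in this assay, at which 2 of the 4 values shown sit.

Going by these compounds, the methyl and the two hydroxyl groups changed together, so their separate contributions stay unknown. On these data alone, whether a 4-hydroxyphenyl or a 3,4-dimethoxyphenyl would behave like compound 3 or compound 4 remains open.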